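The source may hold more compounds than are shown below. What is called first, only, known or untested is meant among the compounds shown, and "the series" means these compounds.

Of the compounds shown here, three sharing one core have been tested in a functional assay on A549 cells (Homo sapiens) for cytotoxicity, read by MTT assay; a lower number here means a stronger inhibitor, a higher number a weaker inhibitor. Compound 1 `N#Cc1c(Nc2ccc(Cl)cc2)c(F)c2nc(N)nc(N)c2c1F` gives 115 ug/mL. Compound 2 `N#Cc1c(NCc2ccccc2)c(F)c2nc(N)nc(N)c2c1F` gives no number in this assay but only a limit, > 1000 ug/mL. For the measured compounds named here, the step of an at least 8.6-fold higher number from compound 1 to compound 2 (0.93 log units; beyond the scatter) is the only change between two measured compounds. Compound 3 `CCN(CC)c1c(C#N)c(F)c2c(N)nc(N)nc2c1Cl` gives 7.1 ug/mL in this assay, the lowest of the two numbers shown; the nearest is compound 1, whose number is higher by a gap beyond the scatter.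

Compound 4 `CCN(CC)c1c(C#N)c(F)c2c(N)nc(N)nc2c1F` differs from compound 3 by fluoro in place of chloro on an aromatic carbon. Going by the values given here, the one measured step, from compound 1 to compound 2, concerns the group on the ring nitrogen and not the halogen on the carbon ring, so it does not bear on this exchange; no measured step does. With nothing to point either way, the expectation is that swapping one halogen for another at this position changes the number little, a step of a 1.4-fold higher number from compound 3 to compound 4 (0.15 log units; within the scatter) that stays within the scatter. Compound 4 is therefore estimated at 10 ug/mL in this assay, with a range from 3 ug/mL to 35 ug/mL.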

Compound 4, half-maximal inhibitory concentration: 26.5 ug/mL
Compound 4: the middle estimate sits 2.7-fold (0.42 log units) below what was measured, and the stated range covers the measured number.
By their numbers in this assay, from the lowest: compound 3; then compound 4; then compound 1. At a limit, above all of these: compound 2.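

The halogen at this position turns out to matter in this assay: fluoro in place of chloro, on the carbon ortho to the diethylamino group, gives a 3.7-fold higher number from compound 3 to compound 4 (0.57 log units; beyond the scatter), so a single-atom exchange moves the number beyond the scatter. With fluoro in place, the group on the other side of the comparison also counts, as diethylamino in place of (4-chlorophenyl)amino gives a 4.3-fold lower number from compound 1 to compound 4 (0.64 log units; beyond the scatter). Diethylamino in place of benzylamino gives an at least 37-fold lower number from compound 2 to compound 4 (1.57 log units; beyond the scatter), a step that rests on a limit for compound 2: the limit of > 1000 ug/mL in this assay, at which 1 of the 4 values shown sits.

For the compounds shown here, only one pair isolates the halogen, so whether chloro keeps its lower number with other amino groups stays open. What a bromo or methyl group would do at this position, or a longer chain in place of the ethyl groups, is also unknown.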